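The source may report more compounds than this note shows. Statements on the series, on what has been measured and on what is new or still open speak of the compounds shown alone.

In an ADME assay on the whole organism with Oryza sativa as the target, tested at 0.1 uM (on this read-out lower numbers stand for a stronger effect and higher numbers for a weaker effect at the one concentration tested), the three measured compounds gave the following numbers:

Compound 1 `C[C@@H](NC(=O)Nc1ccccc1Cl)c1ccccc1`: 101%
Compound 2 `C[C@H](NC(=O)Nc1ccccc1Cl)c1ccccc1`: 99%
Compound 3 `C[C@@H](NC(=O)Nc1cccc(Cl)c1Cl)c1ccccc1`: 100%

Compound 1 is the starting point of the step considered here. Its number in this assay sits close to both others: compounds 1 and 2, which (the fact that compounds 1 and 2 differ only in the configuration as drawn), are separated by a number 2 percentage points lower from compound 1 to compound 2 (within the scatter), and compound 1 and compound 3 by a number 1 percentage points lower from compound 1 to compound 3 (within the scatter). All three numbers thus lie within the usual scatter of one another, and none of the three can be set apart from the rest.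

Compound 4 `C[C@@H](NC(=O)Nc1ccc(Cl)cc1Cl)c1ccccc1` has not yet been measured. It arises from compound 1 by chloro in place of hydrogen on an aromatic carbon. Among the measured compounds shown here, the one measured step that bears on this change is the one from compound 1 to compound 3, where chloro also took the place of hydrogen on an aromatic carbon, and that step was a number 1 percentage points lower from compound 1 to compound 3 (within the scatter). The step from compound 1 to compound 2, being a change of configuration only, says nothing about an added chloro group. With a single precedent of this kind showing no movement beyond the scatter, no step beyond the scatter is expected in this assay in either direction.

Compound 4 is therefore expected to give 100%, in a range from 92% to 108%. For compound 4 this estimate means an expected step of a number 1 percentage points lower from compound 1 to compound 4 (within the scatter), which should stay within the scatter.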

Compound 4, a percentage reported as activity, at one concentration (the size of the read-out at that concentration, not a potency): 101%
Estimate against measurement, compound 4: 1 percentage points below; the measured number falls inside the stated range.
By their numbers in this assay, from the lowest: compounds 2, 3, 1 and 4 (each within the scatter of the next).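

In this assay, the carbon para to a large group and meta to a chloro group takes a chloro group with no change at the digits printed from compound 1 to compound 4 (within the scatter). Together with the earlier change on the same ring, which gave a number 1 percentage points lower from compound 1 to compound 3 (within the scatter), this makes two carbons at which chloro in place of hydrogen has now been read, and neither step lies beyond the scatter, so the absence of movement is no longer tied to a single place on this ring. Nothing in the information at hand bears on why this change leaves the number where it is.

What the compounds shown leave open is whether any group at this carbon would move the number beyond the scatter, since chloro is the only group that enters here and an amine, a carboxylic acid or a longer chain in the same place could behave differently. Also open is whether the other configuration of the chain carbon would matter with this added chloro group, and whether any of these compounds would separate from the others at a concentration other than the one tested.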